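The compounds below may be only part of what the source reports. "The series", "measured", "known", "first", "only" and "open" are said of these compounds alone.

Measured compounds:
compound 1 `COc1ccc(C2CC(c3ccccc3)=NN2C2=NC(=O)/C(=C3\C(=O)Nc4ccccc43)S2)cc1`: 2380 nM
compound 2 `COc1ccc(C2CC(c3ccccc3)=NN2C2=NC(=O)/C(=C3\C(=O)Nc4ccc(Br)cc43)S2)cc1`: 200 nM

Compound 1 gives the highest of the two numbers in a functional assay on cells (Cancer cell lines, Homo sapiens) for cytotoxicity, read by sulforhodamine B assay, with a stated time of 48 h; a lower number here means a stronger inhibitor of growth, a higher number a weaker inhibitor of growth; its nearest neighbour is compound 2, and that step, a 12-fold lower number from compound 1 to compound 2 (1.08 log units; beyond the scatter), comes from bromo in place of hydrogen on an aromatic carbon. Compound 3 `COc1ccc(C2CC(c3ccc4ccccc4c3)=NN2C2=NC(=O)/C(=C3\C(=O)Nc4ccccc43)S2)cc1` has not yet been measured. It differs from compound 1 by naphthalen-2-yl in place of phenyl on a carbon with a double bond to nitrogen. Among the compounds with values here, the one measured step, from compound 1 to compound 2, changes a different part of the shared core, so nothing measured bears directly on this change. Within the data shown here, with no guiding step, the expectation for compound 3 in this assay is a number close to that of compound 1, with a wide range on either side. Compound 3 is therefore estimated at 1800 nM, between 500 nM and 7000 nM, which would mean a step of a 1.3-fold lower number from compound 1 to compound 3 (0.12 log units; within the scatter), expected not to go beyond the scatter.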

Compound 3, concentration for 50% growth inhibition: 620 nM
Beside the measured number, compound 3's estimate is 2.9-fold (0.46 log units) above it; the range from low to high includes it.
By their numbers in this assay, from the lowest: compound 2; then compound 3; then compound 1.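

The carbon with a double bond to nitrogen, in the five-membered non-aromatic ring, now has a measured step of its own in this assay: naphthalen-2-yl in place of phenyl gives a 3.8-fold lower number from compound 1 to compound 3 (0.58 log units; beyond the scatter) and so goes with stronger growth inhibition. This shows that the position responds to what it carries and accepts a group of 10 heavy atoms in place of one of 6, although this step is smaller than the one seen with bromo elsewhere on the shared core. No measurement here explains why the second aromatic ring has this effect.

On these data alone, how a small methyl group, a pyridyl ring or a carboxylic acid would fare at this position remains open. Also open, as far as these compounds go, is whether naphthalen-2-yl and bromo would add up within one compound.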